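The source may hold more compounds than are shown below. What is called first, only, known or untested is meant among the compounds shown, and "the series" means these compounds.

In a functional assay on SK-BR-3 cells (Homo sapiens) for antiproliferative activity, with a stated time of 48 h (a higher number here means that more compound is needed for the effect, a lower number that less compound is needed), three compounds sharing one core have been measured. Compound 1 `O=C(CCCCCCC(=O)Nc1ccc(O)cc1)NO` gives 11000 nM, compound 2 `O=C(CCCCCCC(=O)Nc1cccc(F)c1)NO` gives 1900 nM, and compound 3 `O=C(CCCCCCC(=O)Nc1cccc(C(F)(F)F)c1)NO` gives 26000 nM. Compound 3 therefore holds the highest number of the three, and it stands beyond the scatter from both of the others. Compound 4 `O=C(CCCCCCC(=O)Nc1cccc(Cl)c1)NO` differs from compound 3 in a single group, with chloro in place of trifluoromethyl on an aromatic carbon.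

Among the compounds with values here, one measured step bears directly on this change. Trifluoromethyl in place of fluoro on an aromatic carbon gave a 14-fold higher number from compound 2 to compound 3 (1.14 log units; beyond the scatter), a large step. Compound 4 removes the same trifluoromethyl and puts another halogen where compound 2 carries fluoro. A lower number than that of compound 3 is therefore expected, with a step beyond the scatter. Chloro has not been measured on this core, however, so a full return to the value of compound 2 is not assumed, and the expectation remains uncertain with only this one step behind it. The expected change is a 5.2-fold lower number from compound 3 to compound 4 (0.72 log units; beyond the scatter). For compound 4, the estimated value is 5000 nM, with an expected range from 1600 nM to 15000 nM.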

Compound 4, half-maximal effective concentration: 2000 nM
For compound 4 the middle estimate is 2.5-fold (0.40 log units) above the measured one; the range from low to high includes it.
By their numbers in this assay, from the lowest: compounds 2 and 4 (each within the scatter of the next); then compound 1; then compound 3.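

In this assay, chloro in place of trifluoromethyl on an aromatic carbon gives a 13-fold lower number from compound 3 to compound 4 (1.11 log units; beyond the scatter), so the large earlier step, a 14-fold higher number from compound 2 to compound 3 (1.14 log units; beyond the scatter), now has a counterpart in the opposite direction from a second halogen. Chloro in place of fluoro gives a 1.1-fold higher number from compound 2 to compound 4 (0.02 log units; within the scatter), so this assay does not separate these two halogens at this position, and of the three groups compared here, only trifluoromethyl stands apart from the others. What the earlier compounds could not show is therefore that the single step from fluoro to trifluoromethyl was not a feature of fluoro alone, although nothing shown here gives a reason for the difference.

On these data alone, it remains open whether other groups at this position, such as a methyl, a methoxy, a nitrile or an amine, would fall with the two halogens or with trifluoromethyl. As far as these compounds go, it also remains open whether chloro and trifluoromethyl would differ in the same way on another carbon of the ring, or with a longer or shorter chain in the shared core.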